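The compounds below may be only part of what the source reports. "The series", "measured", "known", "first", "only" and "open" are said of these compounds alone.

Compounds with measured values:
- compound 1 `FC(F)(F)c1ccc(Nc2ncnc3sc(Nc4ccccc4Cl)nc23)cc1`: in a functional assay on HEK293 cells for antagonist activity at transient receptor potential cation channel subfamily V member 1 (Homo sapiens), read by calcium flux (on this read-out higher numbers stand for weaker inhibition and lower numbers for stronger inhibition), compound 1 gives 64 nM
- compound 2 `FC(F)(F)c1ccc(Nc2ncnc3sc(Nc4ccccc4C(F)(F)F)nc23)cc1`: in this assay compound 2 gives 74 nM

Compound 2 holds the higher of the two numbers shown, yet the step between them is a 1.2-fold higher number from compound 1 to compound 2 (0.06 log units; within the scatter), so the two sit together within the scatter. Among the compounds with values here, the single step seen so far changes only one substituent on the anilino ring at the sulfur-bearing end of the shared core, while the move to compound 3 `OCc1cc(Cl)c(Nc2nc3c(Nc4ccc(C(F)(F)F)cc4)ncnc3s2)c(Cl)c1` replaces that ring as a whole: 2,6-dichloro-4-(hydroxymethyl)phenyl in place of 2-(trifluoromethyl)phenyl on a nitrogen on an aromatic ring. Within the data shown here, no measured step covers such a change, so the data give no direction beyond the scatter. Compound 3 is therefore expected to land near compound 2, with a wider range to allow for the larger change, as a 1.6-fold higher number from compound 2 to compound 3 (0.21 log units; within the scatter). The estimate for compound 3 in this assay is 120 nM, between 30 nM and 500 nM.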

Compound 3, half-maximal inhibitory concentration: 1 nM
Compound 3: middle estimate off by 120-fold (2.08 log units), on the high side, and the stated range ends above it.
By their numbers in this assay, from the lowest: compound 3; then compounds 1 and 2 (each within the scatter of the next).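

In this assay, within the data shown here, this position proves far more responsive than the earlier compounds suggested: the exchange of chloro for trifluoromethyl on the anilino ring stayed within the scatter, at a 1.2-fold higher number from compound 1 to compound 2 (0.06 log units; within the scatter), whereas replacing the whole ring gives a 74-fold lower number from compound 2 to compound 3 (1.87 log units; beyond the scatter). Measured against the 2-chlorophenyl group, the same ring gives a 64-fold lower number from compound 1 to compound 3 (1.81 log units; beyond the scatter), so the large step appears from both starting points. Nothing measured here accounts for the size of this step.

The entering 2,6-dichloro-4-(hydroxymethyl)phenyl differs from both earlier groups in more than one feature, and the compounds shown do not separate the share of the chloro groups from that of the hydroxymethyl. On these data alone, it also stays open whether an amine or a carboxylic acid in place of the hydroxymethyl would keep the number this low.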